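The source may hold more compounds than are shown below. What is called first, only, known or untested is meant among the compounds shown, and "the series" means these compounds.

Compound 1 `CCN(C(=O)c1c(O)c2c(Br)cccc2n(C)c1=O)c1ccccc1`: 95%
Compound 2 `CN(C(=O)c1c(O)c2c(C(F)(F)F)cccc2n(C)c1=O)c1ccccc1`: 99%
Compound 3 `CCOc1cccc2c1c(O)c(C(=O)N(C)c1ccccc1)c(=O)n2C`: 40%

These three compounds share one core and were all tested in a functional assay on the whole organism for inhibition, with Mus musculus as the target, at a dose of 1 mg/kg by the oral route; on this read-out lower numbers stand for less inhibition and higher numbers for more inhibition at the one dose given (going by the name of the read-out). Compound 3 gives the lowest of the three numbers: compound 1 gives 95% and compound 2 gives 99%, and both lie beyond the scatter above compound 3. Among the compounds with values here, only one pair of measured compounds differs in a single place, and that is a number 59 percentage points lower from compound 2 to compound 3 (beyond the scatter), a large fall that came with ethoxy in place of trifluoromethyl.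

Compound 4 `CSc1cccc2c1c(O)c(C(=O)N(C)c1ccccc1)c(=O)n2C` differs from compound 3 in one place: methylsulfanyl in place of ethoxy on an aromatic carbon. Within the data shown here, no measured step swaps one of these two groups for the other, so the step from compound 2 to compound 3 bears on it only indirectly: it shows that a change at this same aromatic carbon can move the read-out a great deal. Whether methylsulfanyl behaves more like ethoxy or more like the groups in compound 1 and compound 2 cannot be read from the numbers at hand, so the expectation is wide. Compound 4 is estimated at 55%, in a range from 20% to 90%, which corresponds to an expected step of a number 15 percentage points higher from compound 3 to compound 4 (beyond the scatter), modest and possibly within the scatter.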

Compound 4, a percentage reported as inhibition, in the whole organism at one dose (the size of the read-out at that dose, not a potency): 100%
Estimate against measurement, compound 4: 45 percentage points below; measured number outside the range, above it.
By their numbers in this assay, from the lowest: compound 3; then compounds 1, 2 and 4 (each within the scatter of the next).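

In this assay, methylsulfanyl in place of ethoxy on this aromatic carbon brings a number 60 percentage points higher from compound 3 to compound 4 (beyond the scatter) and so wipes out the whole of the earlier fall: the position can carry a group with a high reading that is not trifluoromethyl, and among the three groups compared here on this carbon, ethoxy alone gives a low reading. Methylsulfanyl and trifluoromethyl cannot be told apart at this one dose, with a number 1 percentage points higher from compound 2 to compound 4 (within the scatter) and so no order between them, even though the two groups share little in their atoms. No measurement in hand explains why two such small groups, ethoxy and methylsulfanyl, read so differently.

As far as these compounds go, the swap changes both the atom attached to the ring and the length of the chain, so it stays open which of the two goes with the large step; methoxy and ethylsulfanyl on this carbon would separate them. Also open, from the compounds shown here alone, are how an amine or a carboxylic acid would read here, and whether compound 2 and compound 4 would stay together at a lower dose.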